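Aryl exchange on the ring nitrogen: compound 2 to compound 4

A few compounds are considered here, and "the series" means these few. Any claim that something is new, unique, unknown or untested is made for them only; others in the source may bear on it.

Measured so far:
compound 1 `COc1ccc(-c2cs/c(=N\NC(=O)c3ccc(O)cc3)n2-c2ccc(OC)cc2OC)cc1`: 3310 nM
compound 2 `O=C(N/N=c1\scc(-c2ccc(Cl)cc2)n1-c1ccc(Cl)cc1Cl)c1ccc(O)cc1`: 3310 nM
compound 3 `Cc1ccc(-c2cs/c(=N\NC(=O)c3ccc(O)cc3)n2-c2c(C)cccc2C)cc1`: 10500 nM

In a functional assay on CAKI-1 cells (Homo sapiens) for cytotoxicity, read by sulforhodamine B assay, with a stated time of 48 h (a lower number here means a stronger inhibitor of growth, a higher number a weaker inhibitor of growth), compound 2 gives 3310 nM, level with compound 1 at the digits shown and, together with it, the lowest of the three numbers; compound 3 sits a clear step higher, beyond the scatter.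

Compound 4 `COc1ccc(-n2c(-c3ccc(Cl)cc3)cs/c2=N\NC(=O)c2ccc(O)cc2)c(OC)c1` is not yet measured. It differs from compound 2 by 2,4-dimethoxyphenyl in place of 2,4-dichlorophenyl on an aromatic nitrogen, at the place on an aromatic nitrogen of the five-membered ring, two ring bonds from the ring sulfur. Compound 1 already carries the 2,4-dimethoxyphenyl on that nitrogen and gives 3310 nM, so no step beyond the scatter is expected. The step from compound 2 to compound 4 is estimated as a 1.0-fold lower number from compound 2 to compound 4 (0.00 log units; within the scatter). Compound 4 is expected near 3300 nM, within 1500 nM to 7500 nM.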

Compound 4, concentration for 50% growth inhibition: 22900 nM
The estimate for compound 4 lay 6.9-fold (0.84 log units) below the measured number; the measured number lies above the stated range.
By their numbers in this assay, from the lowest: compounds 1 and 2 (each within the scatter of the next); then compound 3; then compound 4.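

In this assay, the aryl group on the aromatic nitrogen matters once the 4-chlorophenyl group is present: 2,4-dimethoxyphenyl in place of 2,4-dichlorophenyl gives a 6.9-fold higher number from compound 2 to compound 4 (0.84 log units; beyond the scatter). Chloro in place of methoxy on an aromatic carbon gives a 6.9-fold higher number from compound 1 to compound 4 (0.84 log units; beyond the scatter), so 2,4-dimethoxyphenyl and 4-chlorophenyl, each found in a compound with a lower number, give the higher number only together in compound 4. Nothing available explains this dependence.

Still open, as far as these compounds go, is how an unsubstituted phenyl or a dimethylamino-substituted phenyl on that nitrogen would behave alongside the 4-chlorophenyl group.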